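This account rests on a few compounds, and the source may have more. Where it says the series, first, only, none or still open, it means among the compounds named here.

Three compounds were compared in a functional assay on HCT-116 cells (Homo sapiens) for antiproliferative activity, read by CCK-8 assay, with a stated time of 72 h, tested at 2 uM (on this read-out lower numbers stand for a weaker effect and higher numbers for a stronger effect at the one concentration tested), before a fourth was made. Compound 2 `CC(C)n1cnc2c(Nc3cccc(Cl)c3)nc(NCOCc3ccc(/C=C/C(=O)Nc4ccccc4N)cc3)nc21` gives 18.5% in this assay, and compound 1 `Nc1ccccc1NC(=O)/C=C/c1ccc(COCNc2nc(Nc3cccc(Cl)c3)c3ncn(C4CCCC4)c3n2)cc1` gives 9.04%. The change from compound 2 to compound 1 is cyclopentyl in place of isopropyl on an aromatic nitrogen, and it made a step of a number 9.5 percentage points lower from compound 2 to compound 1 (within the scatter). Compound 3 `CC(C)n1cnc2c(NCc3ccc(C(=O)Nc4ccccc4N)cc3)nc(Cl)nc21` is built on a different core; the difference between the two cores is not broken down here. In this assay compound 3 gives 73.2%, the highest of the three numbers, with both other compounds lying beyond the scatter below it. Compound 4 `Nc1ccccc1NC(=O)c1ccc(CNc2nc(Cl)nc3c2ncn3C2CCCC2)cc1` has not yet been measured in this assay. It differs from compound 3 by cyclopentyl in place of isopropyl on an aromatic nitrogen, the same change as that from compound 2 to compound 1, made at the same place. Since the earlier step stayed within the scatter, the expected step here is a number 6.2 percentage points lower from compound 3 to compound 4 (within the scatter), resting on the earlier pair, which gave a number 9.5 percentage points lower from compound 2 to compound 1 (within the scatter). For compound 4 the estimated result in this assay is therefore 67%, with a likely range from 50% to 82%.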

Compound 4, a percentage reported as inhibition, at one concentration (the size of the read-out at that concentration, not a potency): 75.6%
Compound 4: middle estimate off by 8.6 percentage points, on the low side; the measured number falls inside the stated range.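

In this assay, cyclopentyl in place of isopropyl on the aromatic nitrogen gave a step of a number 2.4 percentage points higher from compound 3 to compound 4 (within the scatter), so on this core too the change did not move the read-out beyond the usual scatter. Set beside the earlier step, the two cores give no sign that the change behaves differently from one to the other: the same change on two cores in this assay, a number 9.5 percentage points lower (within the scatter) from compound 2 to compound 1 and a number 2.4 percentage points higher (within the scatter) from compound 3 to compound 4, 11.9 percentage points apart, within the scatter of two such steps. This supports carrying the change between these two cores without a step that can be told from scatter, but it does not show that the two groups are interchangeable on any other core, and a read-out at a single concentration says nothing about potency.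

The compounds shown leave open whether another group on that aromatic nitrogen, such as cyclohexyl, benzyl or a longer alkyl chain, would give a step beyond the scatter. They also leave open what a group carrying an amine or a hydroxyl would do at the same place.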